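Ester Chain Removed, Leaving Aminomethyl on the Core

This account rests on a few compounds, and the source may have more. Where it says the series, first, only, none or still open, it means among the compounds named here.

Among the compounds with values here, in a functional assay on HeLa cells (Homo sapiens) for cytotoxicity, read by neutral red uptake, with a stated time of 3 days (a lower number here means a stronger inhibitor, a higher number a weaker inhibitor), compound 2 `CN(C)CCC(=O)OCc1c(F)c(N)c2c(=O)cc(-c3ccc(N)c(F)c3)oc2c1F` gives 11000 nM, the only plain number among the values shown. In this assay compound 1 `Nc1ccc(-c2cc(=O)c3c(N)c(F)c(Cl)c(F)c3o2)cc1F` gives > 100000 nM, a limit of the measurement and not a number. Within the data shown here, the step of an at least 9.0-fold lower number from compound 1 to compound 2 (0.95 log units; beyond the scatter) is the only measured change that bears on what follows. Compound 3 `NCc1c(F)c(N)c2c(=O)cc(-c3ccc(N)c(F)c3)oc2c1F` differs from compound 2 by amino in place of ((2-(dimethylamino)ethyl)carbonyl)oxy on a saturated chain carbon bound to an aromatic carbon. Among the measured compounds shown here, no measured step tests this exact swap, so compound 3 is expected to show a step of a 1.4-fold higher number from compound 2 to compound 3 (0.13 log units; within the scatter), within the usual scatter. The estimate for compound 3 is 15000 nM, between 4000 nM and 60000 nM.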

Compound 3, half-maximal inhibitory concentration: 8800 nM
For compound 3 the middle estimate is 1.7-fold (0.23 log units) above the measured one; the measured number falls inside the stated range.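

In this assay, most of the ester chain can go with no readable change: the step to the much smaller amino is a 1.3-fold lower number from compound 2 to compound 3 (0.10 log units; within the scatter). Set against the chloro group on the aromatic carbon, the short aminomethyl group alone gives an at least 11-fold lower number from compound 1 to compound 3 (1.05 log units; beyond the scatter), so the long chain is not required for this gain. Compound 1 stands at a limit and not a number, so this step has no upper end: the limit of > 100000 nM in this assay, at which 1 of the 3 values shown sits. Going by these compounds, whether a hydroxymethyl or a plain methyl group in this place would match aminomethyl stays open, and so does the effect of a longer aminoethyl chain.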